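Adding a 2-hydroxyethoxy group to compound 3

The compounds below may be only part of what the source reports. "The series", "measured", "known", "first", "only" and "open" are said of these compounds alone.

Three amides on the shared core have been looked at: compound 1 `Cc1ccc(C(=O)Nc2ncc(Cc3cccc(C(F)(F)F)c3)s2)cc1C`, compound 2 `COc1cccc(C(=O)Nc2ncc(Cc3cccc(C(F)(F)F)c3)s2)c1` and compound 3 `COc1ccc(C(=O)Nc2ncc(Cc3cccc(C(F)(F)F)c3)s2)cc1`. In an assay on microsomes for inhibition of acyl-CoA 6-desaturase (Homo sapiens), tested at 10 uM (on this read-out lower numbers stand for less inhibition and higher numbers for more inhibition at the one concentration tested (going by the name of the read-out)), compound 2 gives 53%. In this assay, among the compounds with values here, compound 1 is recorded as "not determined" (no result reported), and in this assay compound 3 likewise is recorded as "not determined" (no result reported); so compound 3 stands without a measured value, and no step between measured compounds can be drawn to it.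

Compound 4 `COc1ccc(C(=O)Nc2ncc(Cc3cccc(C(F)(F)F)c3)s2)cc1OCCO` is the next entry. Relative to compound 3 the change is 2-hydroxyethoxy in place of hydrogen on an aromatic carbon. Going by these compounds, with no number for compound 3, the size of the step in this assay cannot be anchored; a shift of either sign, or none beyond the scatter, is equally open.

Compound 4 is expected to give about 45% in this assay, within roughly 15% to 75%, a level set mainly because the related compound 2 gives 53%.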

Compound 4, a percentage reported as inhibition, at one concentration (the size of the read-out at that concentration, not a potency): 15%
The estimate for compound 4 lay 30 percentage points above the measured number, within the range that was stated.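

No step can be read between compound 3 and compound 4 in this assay, so compound 4 at 15% stands alone. The compounds shown leave open whether adding 2-hydroxyethoxy shifts this read-out, and in which direction. Nothing at hand bears on this result.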